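The source may hold more compounds than are shown below. What is called first, only, known or untested is meant among the compounds shown, and "the series" means these compounds.

Measured in a functional assay on L1210 cells (Mus musculus) for antiproliferative activity, read by MTT assay, with a stated time of 72 h; on this read-out lower numbers stand for stronger inhibition and higher numbers for weaker inhibition:
Compound 1 `COc1ccc(C2=NN(C(C)=O)C(c3ccc([N+](=O)[O-])cc3)O2)cc1`: 68000 nM
Compound 2 `COc1ccc(C2=NN(C(C)=O)C(c3ccc(OC)cc3)O2)cc1`: > 100000 nM. This value is a limit of the assay, not a number.
Compound 3 `COc1ccc(C2=NN(C(C)=O)C(c3ccccc3OC)O2)cc1`: 5800 nM

Of the two true numbers, the lower belongs to compound 3, at 5800 nM, and the higher to compound 1, at 68000 nM. Compound 4 `COc1ccc(C2=NN(C(C)=O)C(c3ccccc3)O2)cc1` has not yet been measured. It departs from compound 3 in one place, with hydrogen in place of methoxy on an aromatic carbon, ortho to a large group: hydrogen in place of methoxy on an aromatic carbon. The closest evidence is an at least 17-fold lower number from compound 2 to compound 3 (1.23 log units; beyond the scatter), a large step that came with 2-methoxyphenyl in place of 4-methoxyphenyl on a saturated ring carbon. The other step, an at least 1.4-fold higher number from compound 1 to compound 2 (0.16 log units; that floor lies within the scatter), has a floor within the scatter and offers little guidance. Among the compounds with values here, no measured step removes this methoxy outright. A higher number is therefore expected in this assay, beyond the scatter but short of the full distance to the limit of compound 2. The expected change is a 5.2-fold higher number from compound 3 to compound 4 (0.71 log units; beyond the scatter). Compound 4 is estimated at 30000 nM, with an expected range of 9000 nM to 100000 nM.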

Compound 4, half-maximal inhibitory concentration: > 100000 nM
Compound 4 gave a limit, no number; the forecaster's own chance of this, stated with the estimate: 20%; middle value at least 3.3-fold (0.52 log units) from the limit.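

In this assay compound 4 gives > 100000 nM, which is a limit of the assay and not a number. Taking the methoxy away, so that 2-methoxyphenyl becomes phenyl, gives an at least 17-fold higher number from compound 3 to compound 4 (1.23 log units; beyond the scatter); the earlier compounds showed only a change from 4-methoxyphenyl to 2-methoxyphenyl, whereas this result shows that the measurable value of compound 3 is lost when no group replaces the methoxy at this place. Hydrogen in place of nitro gives an at least 1.4-fold higher number from compound 1 to compound 4 (0.16 log units; that floor lies within the scatter), and the step between compound 2 and compound 4 cannot be read, since both values are limits: the limit of > 100000 nM in this assay, at which 2 of the 4 values shown sit.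

The compounds shown leave open whether a hydroxyl, an amine or an ethoxy group at this place would keep compound 3 near 5800 nM. They also leave open how far compound 2 and compound 4 lie past the limit.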